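The compounds below may be only part of what the source reports. "The series", "measured", "known", "first", "only" and "open" are said of these compounds alone.

In a functional assay on DU-145 cells (Homo sapiens) for inhibition (on this read-out higher numbers stand for weaker inhibition and lower numbers for stronger inhibition), compound 1 `CCOc1ccc(Br)cc1-c1cc(Nc2ccc(C#N)cc2)nc(N)n1` gives 400 nM. Compound 2 `CCOc1ccc(Br)cc1-c1cc(Nc2ccc(C(=O)NO)cc2)nc(N)n1` stands at > 1000 nM, which is a limit and not a number. Compound 3 `CCOc1ccc(Br)cc1-c1cc(Nc2ccc(C(C)=O)cc2)nc(N)n1` differs from it as follows: methyl in place of hydroxyamino on a carbonyl carbon. Within the data shown here, the one measured step bearing on this is an at least 2.5-fold higher number from compound 1 to compound 2 (0.39 log units; beyond the scatter), with hydroxycarbamoyl in place of cyano on an aromatic carbon. Since compound 3 no longer carries hydroxycarbamoyl, a move of similar size towards stronger inhibition is expected in this assay. The expected step is an at least 2.0-fold lower number from compound 2 to compound 3 (0.30 log units; that floor lies within the scatter). Compound 3 is estimated at 500 nM, with an expected range of 180 nM to 1400 nM.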

Compound 3, half-maximal inhibitory concentration: 90 nM
Beside the measured number, compound 3's estimate is 5.6-fold (0.74 log units) above it, outside the stated range (below it).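

Acetyl in place of cyano on an aromatic carbon strengthens inhibition in this assay, with a 4.4-fold lower number from compound 1 to compound 3 (0.65 log units; beyond the scatter), whereas hydroxycarbamoyl at this place weakened it. With the carbonyl kept, methyl in place of hydroxyamino gives an at least 11-fold lower number from compound 2 to compound 3 (1.04 log units; beyond the scatter), so a carbonyl at this place is compatible with stronger inhibition and the weak result tracks the hydroxyamino part. Compound 2 stands at a limit, not a number: the limit of > 1000 nM in this assay, at which 1 of the 3 values shown sits.

On these data alone, whether a longer chain such as propanoyl keeps this strength remains open. So does the effect of an amine or a hydroxyl on the same carbonyl carbon, which would give a primary amide or a carboxylic acid.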